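Replacing the octyl end of compound 3 with 2-phenylethynyl

This account rests on a few compounds, and the source may have more. Where it says the series, first, only, none or still open, it means among the compounds named here.

Within the data shown here, in a functional assay on cells (T-cell line, Homo sapiens) for inhibition (on this read-out lower numbers stand for stronger inhibition and higher numbers for weaker inhibition), compound 3 (`CCCCCCCCCN1CCC(COC(c2ccccc2)c2ccccc2)CC1`) gives 700 nM, the lowest of the three numbers so far. Compound 1 (`Clc1ccc(CCCN2CCC(COC(c3ccccc3)c3ccccc3)CC2)cc1Cl`) gives 2200 nM and compound 2 (`CCCCCN1CCC(COC(c2ccccc2)c2ccccc2)CC1`) gives 10800 nM. Next is compound 4 (`C(#Cc1ccccc1)CN1CCC(COC(c2ccccc2)c2ccccc2)CC1`), with 2-phenylethynyl in place of octyl on a saturated chain carbon bound to an amine nitrogen in a ring. Cut one bond further out, the change reads nonyl to 3-phenylprop-2-yn-1-yl.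

Among the measured compounds shown here, two measured steps bear on it. The modest step is a 3.1-fold lower number from compound 1 to compound 3 (0.50 log units; beyond the scatter), and the large one is a 15-fold lower number from compound 2 to compound 3 (1.19 log units; beyond the scatter). Compound 4 shares with compound 1 an aromatic ring on the chain, so compound 1 at 2200 nM is the closer guide, and a full return to the level of compound 2 is not expected. A modest to large rise in this assay is expected. The estimated step is a 5.0-fold higher number from compound 3 to compound 4 (0.70 log units; beyond the scatter). For compound 4 the estimated value is 3500 nM, with an expected range of 1300 nM to 10000 nM.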

Compound 4, half-maximal inhibitory concentration: > 20000 nM
Compound 4 was reported as a limit; the forecaster's own chance of this, stated with the estimate: 5%; at least 5.7-fold (0.75 log units) between middle value and limit.
By their numbers in this assay, from the lowest: compound 3; then compound 1; then compound 2. At a limit, above all of these: compound 4.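

In this assay compound 4 stands only as a limit: the limit of > 20000 nM in this assay, at which 1 of the 4 values shown sits.

On a saturated chain carbon bound to an amine nitrogen in a ring, the number of heavy atoms alone does not set the level: octyl and 2-phenylethynyl both hold 8 heavy atoms, yet the series shows an at least 28-fold higher number from compound 3 to compound 4 (1.45 log units; beyond the scatter). An aromatic ring on the chain does not by itself hold the level of the dichlorophenyl analogue either, as shown by an at least 9.0-fold higher number from compound 1 to compound 4 (0.95 log units; beyond the scatter), while the comparison with the pentyl analogue gives an at least 1.8-fold higher number from compound 2 to compound 4 (0.26 log units; that floor lies within the scatter), so compound 4 cannot be separated from compound 2.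

As far as these compounds go, whether the loss follows the triple bond or the unsubstituted phenyl ring remains open. A saturated 3-phenylpropyl group or a phenylpropenyl group on the same chain carbon would bear on that question.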